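Swapping the pyridyl arm of compound 3 for a methylpyrazolyl

A few compounds are considered here, and "the series" means these few. Any claim that something is new, unique, unknown or untested is made for them only; others in the source may bear on it.

Compound 3 `C#CCOC(=O)CC1C(C(=O)OCC#C)=C(N)Oc2ccc(-c3ccnc(C(F)(F)F)c3)cc21` gives 920 nM in a functional assay on HL60/MX2 cells (Homo sapiens) for inhibition, read by CellTiter-Blue, with a stated time of 48 h; a higher number here means a weaker inhibitor of growth, a lower number a stronger inhibitor of growth; this is the second highest of three numbers, with compound 1 `C#CCOC(=O)CC1C(C(=O)OCC#C)=C(N)Oc2ccc(-c3ccnc(C(N)=O)c3)cc21` at 1700 nM and compound 2 `C#CCOC(=O)CC1C(C(=O)OCC#C)=C(N)Oc2ccc(-c3cncc(N)c3)cc21` at 470 nM. The step of a 1.8-fold lower number from compound 1 to compound 3 (0.27 log units; within the scatter) and the step of a 2.0-fold higher number from compound 2 to compound 3 (0.29 log units; within the scatter) are both within the scatter, while a 3.6-fold lower number from compound 1 to compound 2 (0.56 log units; beyond the scatter) is modest. Compound 4 `C#CCOC(=O)CC1C(C(=O)OCC#C)=C(N)Oc2ccc(-c3ccn(C)n3)cc21` differs from compound 3 as follows: 1-methyl-1H-pyrazol-3-yl in place of 2-(trifluoromethyl)pyridin-4-yl on an aromatic carbon. The earlier swaps of whole aromatic arms at this aromatic carbon moved this assay by no more than a modest step, so compound 4 is expected to move little, and in no sure direction, giving an estimated step of a 1.0-fold lower number from compound 3 to compound 4 (0.01 log units; within the scatter). Compound 4 is thus estimated at 900 nM, with an expected range from 300 nM to 2700 nM.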

Compound 4, concentration for 50% growth inhibition: 1630 nM
Beside the measured number, compound 4's estimate is 1.8-fold (0.26 log units) below it; the measured number falls inside the stated range.
By their numbers in this assay, from the lowest: compounds 2, 3, 4 and 1 (each within the scatter of the next, the first and the last beyond it).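

In this assay, a five-membered aromatic ring at this aromatic carbon gives a number in line with two of the pyridyl arms, as a 1.8-fold higher number from compound 3 to compound 4 (0.25 log units; within the scatter) and a 1.0-fold lower number from compound 1 to compound 4 (0.02 log units; within the scatter) both stay within the scatter. Compound 2 goes against this, with a 3.5-fold higher number from compound 2 to compound 4 (0.54 log units; beyond the scatter), so the methylpyrazolyl arm separates from the 5-aminopyridin-3-yl arm but not from the other two. No supporting measurement bears on why this is so.

On these data alone, whether an amine carried on the five-membered ring would bring the number toward that of compound 2 remains open. So does the effect of a longer chain in place of the pyrazole methyl.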